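This account rests on a few compounds, and the source may have more. Where it says the series, first, only, none or still open, it means among the compounds named here.

Working notes on the series.

Compound 1 `NC(=O)c1c(NC(=O)c2ccccc2F)sc2c1CCN(C(=S)Nc1ccccc1Cl)C2` gives 11100 nM in a functional assay on MKN-74 cells (Homo sapiens) for antiproliferative activity, with a stated time of 24 h; on this read-out higher numbers stand for weaker inhibition and lower numbers for stronger inhibition. Compound 2 `NC(=O)c1c(NC(=O)c2ccccc2F)sc2c1CCN(C(=O)Nc1ccccc1Cl)C2` gives 49600 nM, and the difference between them, (a group of 10 heavy atoms (7 carbon, 1 nitrogen, 1 oxygen, 1 chlorine; one six-membered aromatic ring of carbon only) in place of a group of 10 heavy atoms (7 carbon, 1 nitrogen, 1 sulfur, 1 chlorine; one six-membered aromatic ring of carbon only), on an amine nitrogen in a ring), produced a 4.5-fold higher number from compound 1 to compound 2 (0.65 log units; beyond the scatter). Compound 3 `NC(=O)c1c(NC(=O)c2ccc(C(F)(F)F)cc2)sc2c1CCN(C(=S)Nc1ccccc1Cl)C2` has a core that differs from that of compound 1 by 4-(trifluoromethyl)phenyl in place of 2-fluorophenyl on a carbonyl carbon. In this assay compound 3 gives 16400 nM; the change made a 1.5-fold higher number from compound 1 to compound 3 (0.17 log units; within the scatter).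

Compound 4 `NC(=O)c1c(NC(=O)c2ccc(C(F)(F)F)cc2)sc2c1CCN(C(=O)Nc1ccccc1Cl)C2` is not yet measured. It differs from compound 3 by a group of 10 heavy atoms (7 carbon, 1 nitrogen, 1 oxygen, 1 chlorine; one six-membered aromatic ring of carbon only) in place of a group of 10 heavy atoms (7 carbon, 1 nitrogen, 1 sulfur, 1 chlorine; one six-membered aromatic ring of carbon only), on an amine nitrogen in a ring, the same kind of change as that from compound 1 to compound 2, at the same kind of place. Because a 4.5-fold higher number from compound 1 to compound 2 (0.65 log units; beyond the scatter) lies beyond the scatter, a step of comparable size is expected here, so that the step from compound 3 to compound 4 is estimated at a 4.0-fold higher number from compound 3 to compound 4 (0.60 log units; beyond the scatter). Compound 4 is therefore expected to give about 65000 nM, with a plausible range from 30000 nM to 150000 nM; this rests on a single measured pair, so it is tentative.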

Compound 4, half-maximal inhibitory concentration: 43900 nM
For compound 4 the middle estimate is 1.5-fold (0.17 log units) above the measured one; low and high end bracket the measured number.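

In this assay, (2-chlorophenyl)carbamoyl in place of its sulfur-containing counterpart on an amine nitrogen in a ring gives a 2.7-fold higher number from compound 3 to compound 4 (0.43 log units; beyond the scatter), and this step carries from one core to the other with no difference in size beyond the scatter: the same change on two cores in this assay, a 4.5-fold higher number (0.65 log units; beyond the scatter) from compound 1 to compound 2 and a 2.7-fold higher number (0.43 log units; beyond the scatter) from compound 3 to compound 4, 1.7-fold (0.22 log units) apart, within the scatter of two such steps. On the core bearing (2-chlorophenyl)carbamoyl, 4-(trifluoromethyl)phenyl in place of 2-fluorophenyl on a carbonyl carbon gives a 1.1-fold lower number from compound 2 to compound 4 (0.05 log units; within the scatter), which likewise matches the step on the other core: the same change on two cores in this assay, a 1.5-fold higher number (0.17 log units; within the scatter) from compound 1 to compound 3 and a 1.1-fold lower number (0.05 log units; within the scatter) from compound 2 to compound 4, 1.7-fold (0.22 log units) apart, within the scatter of two such steps. These are only two cores in a single assay, so neither transfer to further cores nor the origin of either step is shown.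

Still open, from the compounds shown here alone, is how a longer chain or an amine in place of these aromatic groups on the carbonyl carbon would behave. Going by these compounds, it is also open whether the step on the ring nitrogen would persist with a carboxylic acid on that aromatic ring.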